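The compounds below may be only part of what the source reports. "The series", "measured", "known", "first", "only" and "open" are said of these compounds alone.

Among the measured compounds shown here, compound 2 `O=S(=O)(c1ccccc1)N(CCCCCCN1C[C@H](O)[C@@H](O)[C@H](O)[C@H]1CO)C1CCCCC1` gives 280000 nM in an ADME assay on Huh-7 cells (Homo sapiens) for cytotoxicity, read by MTT assay; a higher number here means that more compound is tolerated, a lower number that less compound is tolerated; of the two values of this series it is the only one that is a number. Compound 1 `O=C(c1cc(F)c(F)cc1F)N(CCCCCCN1C[C@H](O)[C@@H](O)[C@H](O)[C@H]1CO)C1CCCCC1` sits at a limit of this assay, > 500000 nM. For the measured compounds named here, the one step measured in this assay, an at least 1.7-fold lower number from compound 1 to compound 2 (0.25 log units; that floor lies within the scatter), is bounded only by the limit of > 500000 nM in this assay, at which 1 of the 2 values shown sits, and stays within the scatter.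

Compound 3 `CC(C)(C)NC(=O)N(CCCCCCN1C[C@H](O)[C@@H](O)[C@H](O)[C@H]1CO)C1CCCCC1` differs from compound 2 as (tert-butyl)carbamoyl in place of phenylsulfonyl on an amine nitrogen. Going by the values given here, no measured step exchanges the group on this amine nitrogen for a carbamoyl, so the only guide is the one step from compound 1 to compound 2, which showed no clear movement. In this assay compound 3 is therefore expected to show at most a small change, a 1.4-fold higher number from compound 2 to compound 3 (0.15 log units; within the scatter), with a fair chance that only a limit is reported. The estimate for compound 3 is 400000 nM, between 150000 nM and 1000000 nM.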

Compound 3, half-maximal cytotoxic concentration: > 500000 nM
Compound 3 gave a limit, no number; the forecaster's own chance of this, stated with the estimate: 40%; at least 1.2-fold (0.09 log units) between middle value and limit.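

Exchanging phenylsulfonyl for (tert-butyl)carbamoyl on the amine nitrogen gives an at least 1.7-fold higher number from compound 2 to compound 3 (0.25 log units; that floor lies within the scatter) in this assay, so this exchange shows no clear movement. Compound 3, whose group has no ring, stands at a limit of this assay, as does compound 1, whose group carries a six-membered aromatic ring, so a ring in this group does not separate the two. The steps between compound 1 and compound 3 cannot be read, and this position cannot be ranked further: the limit of > 500000 nM in this assay, at which 2 of the 3 values shown sit.

Where compound 1 and compound 3 truly lie beyond the limit remains open. Also open, going by these compounds, is whether a primary amine or a carboxylic acid in the group on this nitrogen, or a longer chain to the shared core, would bring a clear change in this assay.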